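Piperazine amides on a shared core: dropping the trifluoromethyl

The source may hold more compounds than are shown below. What is called first, only, known or untested is meant among the compounds shown, and "the series" means these compounds.

Measured so far:
compound 1 `CC1(c2ccccc2)CC(=O)N(CC(=O)N2CCN(c3ccccc3Cl)CC2)C1=O`: "not active" (no number reported)
compound 2 `CC1(c2ccccc2)CC(=O)N(CC(=O)N2CCN(c3cccc(C(F)(F)F)c3)CC2)C1=O`: 300 mg/kg

Compound 2 stands alone with a number. In a functional assay on the whole organism (strain CD-1) with Mus musculus as the target, in the maximal electroshock model, with a stated time of 2 h (a higher number here means that more compound is needed for the effect, a lower number that less compound is needed), compound 2 gives 300 mg/kg. In this assay compound 1 is recorded as "not active" (no number reported), with no dose attached. Going by the values given here, the two values together show only that one compound of the pair reaches an effect at a reported dose and the other does not; no step between two measured compounds is available, so no direction of change has yet been read from the series.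

Compound 3 `CC1(c2ccccc2)CC(=O)N(CC(=O)N2CCN(c3ccccc3)CC2)C1=O` differs from compound 2 by hydrogen in place of trifluoromethyl on an aromatic carbon. The change sits on an aromatic carbon of a six-membered aromatic ring of carbon only, on the phenyl attached to the piperazine; the shared core is untouched.

Among the compounds with values here, with a single number and no measured step, the move from compound 2 to compound 3 is expected to be no change at the digits printed from compound 2 to compound 3 (within the scatter), that is, none beyond the usual scatter. Compound 3 is expected to give 300 mg/kg in this assay, within 150 mg/kg to 600 mg/kg, with a real chance that only an inactive outcome is reported.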

Compound 3, minimum effective dose: "not active" (no number reported)
For compound 3 the study gives words and no number; no gap can be computed for the estimate.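

In this assay, going by these compounds alone, compound 2 gives 300 mg/kg and compound 3 is recorded as "not active" (no number reported) with no dose attached, so no step between these two compounds can be read. The compounds shown leave open whether any other group on the phenyl attached to the piperazine would give a numerical dose. Nothing available bears on this outcome.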